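This account rests on a few compounds, and the source may have more. Where it says the series, first, only, none or still open, it means among the compounds named here.

Working notes on the series. In a functional assay on a cell-free system (Platelet, plasma, Homo sapiens) for inhibition (on this read-out higher numbers stand for weaker inhibition and lower numbers for stronger inhibition), compound 1 (`Cc1ccc(N(CCN2CCC(OCC(=O)O)CC2)C(=O)c2cccc(F)c2)cc1`) gives 160 nM as its half-maximal inhibitory concentration. Compound 2 (`Cc1ccc(N(CCN2CCC(OCC(=O)O)CC2)C(=O)c2cccc(C)c2)cc1`) gives 160 nM on the same read-out, which leaves it level with compound 1, its nearest measured neighbour.

Compound 3 (`COc1cccc(C(=O)N(CCN2CCC(OCC(=O)O)CC2)c2ccc(C)cc2)c1`) has not yet been measured. It differs from compound 2 by methoxy in place of methyl on an aromatic carbon, meta to a large group (methoxy in place of methyl on an aromatic carbon). The same difference reads as 3-methylphenyl to 3-methoxyphenyl.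

For the measured compounds named here, only one measured step bears on this change: methyl in place of fluoro on an aromatic carbon, which reads no change at the digits printed from compound 1 to compound 2 (within the scatter) and stays within the scatter. Going by the values given here, no measured compound carries methoxy, so this single step is thin support. On the evidence of that flat step, no shift beyond the scatter is expected in this assay and no clear direction can be assigned. The expected step is a 1.1-fold higher number from compound 2 to compound 3 (0.03 log units; within the scatter) as a working estimate. Compound 3 is expected at 170 nM with an estimated range from 70 nM to 400 nM on this read-out.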

Compound 3, half-maximal inhibitory concentration: 32 nM
Compound 3: the middle estimate sits 5.3-fold (0.73 log units) above what was measured; measured number below the stated range.
By their numbers in this assay, from the lowest: compound 3; then compounds 1 and 2 (each within the scatter of the next).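

Working from this assay, the position on the aromatic ring, meta to a large group, looked indifferent while only fluoro and methyl had been read there, but methoxy shows that it can respond: the change gives a 5.0-fold lower number from compound 2 to compound 3 (0.70 log units; beyond the scatter), and the change from fluoro gives a 5.0-fold lower number from compound 1 to compound 3 (0.70 log units; beyond the scatter). The two steps match at the digits printed, so on these three compounds methoxy stands apart from both fluoro and methyl, and the change from methyl brings in an oxygen counted as a hydrogen-bond acceptor. No measurement on these compounds accounts for the gain.

The compounds shown leave open whether the gain goes with the oxygen or with the larger group as such, a question that ethyl or hydroxy at this place would address. They also leave open whether a longer chain such as ethoxy carries the gain further, and whether the step holds when another part of the shared core changes.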